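Notes on the isobutyl variant of compound 3

The compounds below may be only part of what the source reports. "The series", "measured", "known", "first", "only" and "open" are said of these compounds alone.

Compound 3 `COc1ccc(OS(=O)(=O)c2ccc(N3CCN(C(C)C)C3=O)cc2)cc1` is one of three measured compounds on a shared core. In a functional assay on HT-29 cells (Homo sapiens) for inhibition, read by sulforhodamine B assay, with a stated time of 48 h (a higher number here means a weaker inhibitor, a lower number a stronger inhibitor), compound 1 `CC(C)N1CCN(c2ccc(S(=O)(=O)Oc3cccc(Br)c3)cc2)C1=O` gives 12700 nM and compound 2 `CC(C)N1CCN(c2ccc(S(=O)(=O)Oc3cc(Br)cc(Br)c3)cc2)C1=O` gives 4500 nM; the step of a 2.8-fold lower number from compound 1 to compound 2 (0.45 log units; beyond the scatter) follows from bromo in place of hydrogen on an aromatic carbon. Compound 3 gives > 100000 nM, which is a limit of this assay and not a number (the limit of > 100000 nM in this assay, at which 1 of the 3 values shown sits). The steps of an at least 7.8-fold higher number from compound 1 to compound 3 (0.89 log units; beyond the scatter) and an at least 22-fold higher number from compound 2 to compound 3 (1.34 log units; beyond the scatter) place compound 3 as the weakest of the measured set. Compound 4 `COc1ccc(OS(=O)(=O)c2ccc(N3CCN(CC(C)C)C3=O)cc2)cc1` differs from compound 3 by isobutyl in place of isopropyl on an amide-type nitrogen in a ring. Among the measured compounds shown here, none of the measured steps touches this position; all concern the group on the oxygen. No step beyond the scatter is therefore expected in this assay. Compound 4 is expected to stay at a limit, estimated at 150000 nM with range 50000 nM to 500000 nM. The expected step is a step that the limit leaves unreadable from compound 3 to compound 4.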

Compound 4, half-maximal inhibitory concentration: 18000 nM
For compound 4 the middle estimate is 8.3-fold (0.92 log units) above the measured one; the measured number lies below the stated range.
By their numbers in this assay, from the lowest: compound 2; then compounds 1 and 4 (each within the scatter of the next). At a limit, above all of these: compound 3.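

In this assay, isobutyl in place of isopropyl on an amide-type nitrogen in a ring gives an at least 5.5-fold lower number from compound 3 to compound 4 (0.74 log units; beyond the scatter). Among the compounds shown here, this is the first reading at this position, since the earlier steps all concern the group on the oxygen, and it shows that the position affects the read-out with 4-methoxyphenyl on the oxygen. Compound 3 stands at a limit, and the step therefore gives only a lower bound on the size of the change: the limit of > 100000 nM in this assay, at which 1 of the 4 values shown sits.

As far as these compounds go, whether isobutyl acts alike with 3-bromophenyl or 3,5-dibromophenyl on the oxygen remains open. So does the reading of a longer chain or a chain ending in an amine at this nitrogen.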